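Bromo in place of fluoro: cytotoxicity notes on the series

The compounds below may be only part of what the source reports. "The series", "measured", "known", "first", "only" and "open" are said of these compounds alone.

Measured so far:
compound 1 `NC(=O)c1nccnc1O`: > 250000 nM
compound 2 `NC(=O)c1nc(F)cnc1O`: > 250000 nM

In an ADME assay on MDCK cells (Canis lupus familiaris) for cytotoxicity, read by microscopy, with a stated time of 3 days (on this read-out higher numbers stand for lower toxicity in this test and lower numbers for higher toxicity in this test), compound 1 gives > 250000 nM, which is a limit of the assay and not a number. Compound 2 gives > 250000 nM in this assay, again a limit rather than a number. The step that the two limits leave unreadable from compound 1 to compound 2 is therefore of unreadable size; all that can be said is the limit of > 250000 nM in this assay, at which 2 of the 2 values shown sit. Compound 2 thus stands at the limit of this assay, with no number of its own.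

Compound 3 `NC(=O)c1nc(Br)cnc1O` differs from compound 2 by bromo in place of fluoro on an aromatic carbon. Going by the values given here, the only measured step bearing on this change, a step that the two limits leave unreadable from compound 1 to compound 2, gives no readable size, so the data offer no step in either direction to carry forward. No step beyond the scatter is therefore expected in this assay from the change to bromo. Because the limit of > 250000 nM in this assay, at which 2 of the 2 values shown sit, holds both measured values, compound 3 is expected to sit at that limit as well. Compound 3 is estimated at 250000 nM, with a range from 100000 nM to 500000 nM. The expected step is a number no higher from compound 2 to compound 3 (the limit leaves the size open).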

Compound 3, minimum cytotoxic concentration: > 250000 nM
Compound 3 gave a limit, no number; the forecaster's own chance of this, stated with the estimate: 85%; the middle value lies on the limit itself.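

In this assay compound 3 gives > 250000 nM, which is a limit and not a number. No new step can be read among compound 1, compound 2 and compound 3, and the series stands at: the limit of > 250000 nM in this assay, at which 3 of the 3 values shown sit. The compounds shown leave open how hydrogen, fluoro and bromo compare on the shared core, and at what concentration any of them becomes cytotoxic.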